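Tert-Butyl for Methyl on Two Related Cores

The source may hold more compounds than are shown below. What is called first, only, known or untested is meant among the compounds shown, and "the series" means these compounds.

Compound 1 `Cc1cc2[nH]nc(N)c2c(=O)[nH]1` and compound 2 `CC(C)(C)c1cc2[nH]nc(N)c2c(=O)[nH]1` share one core and differ in a single group. In an assay on isolated protein for inhibition of ribosomal protein S6 kinase alpha-5 (Homo sapiens), read by mobility shift assay, tested at 30 uM (on this read-out higher numbers stand for more inhibition at the one concentration tested (going by the name of the read-out) and lower numbers for less inhibition), compound 1 gives 56%, and compound 2 gives 65%. The change between them is tert-butyl in place of methyl on an aromatic carbon, and it made a step of a number 9 percentage points higher from compound 1 to compound 2 (within the scatter).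

Compound 3 `Cc1cc2nn(-c3ccccc3)c(N)c2c(=O)[nH]1` is built on a different core; the difference between the cores of compound 1 and compound 3 is not broken down here. In this assay compound 3 gives 4%, the lowest of the three numbers and beyond the scatter from both others.

Compound 4 `CC(C)(C)c1cc2nn(-c3ccccc3)c(N)c2c(=O)[nH]1` has not been measured. It differs from compound 3 by tert-butyl in place of methyl on an aromatic carbon, the same change as between compound 1 and compound 2, at the same place on the ring. The step is expected to be small, a number 6 percentage points higher from compound 3 to compound 4 (within the scatter), because the earlier step of a number 9 percentage points higher from compound 1 to compound 2 (within the scatter) stayed within the scatter. Compound 4 is therefore estimated at 10%, most likely between 0% and 25%.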

Compound 4, a percentage reported as inhibition, at one concentration (the size of the read-out at that concentration, not a potency): -1%
Beside the measured number, compound 4's estimate is 11 percentage points above it; the whole stated range lies above it.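

In this assay, putting tert-butyl in place of methyl on the core of compound 3 gives a step of a number 5 percentage points lower from compound 3 to compound 4 (within the scatter), so this core shows neither a gain nor a loss from the change. Set beside the earlier step, the result gives no sign that the change behaves differently on the two cores: the same change on two cores in this assay, a number 9 percentage points higher (within the scatter) from compound 1 to compound 2 and a number 5 percentage points lower (within the scatter) from compound 3 to compound 4, 14 percentage points apart, within the scatter of two such steps. Going by these compounds alone, this is agreement between only two pairs of compounds, however, and it does not show that the change has no effect or that it would carry over to any other core; on the core of compound 3, both numbers also lie so close to zero that a further fall would have little room to appear.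

The compounds shown leave open how an amine, a carboxylic acid or a longer chain would read at this aromatic carbon in place of methyl or tert-butyl. They also leave open whether any such group would give matching steps on the two cores.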